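Swapping the methylphenyl arm for nitrophenyl

The source may hold more compounds than are shown below. What is called first, only, known or untested is meant among the compounds shown, and "the series" means these compounds.

Compound 2 `Cc1ccnc(NC(c2ccccc2C)c2ccc3cccnc3c2O)c1` was tested in an assay for inhibition of protein disulfide-isomerase (Homo sapiens), with a stated time of 1 h; a higher number here means a weaker inhibitor, a lower number a stronger inhibitor. In this assay compound 2 gives only a limit, > 40000 nM, rather than a number. The other measured compound, compound 1 `Oc1ccc2scnc2c1C(c1ccc(F)cc1)N1CCCCC1`, also reaches only a limit in this assay, > 100000 nM. Compound 2 therefore stands at one of the two limits shown: one value sits at the limit of > 40000 nM in this assay, at which 1 of the 2 values shown sits, the other at the limit of > 100000 nM in this assay, at which 1 of the 2 values shown sits, and no step between measured compounds can be read from these two entries.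

Compound 3 `Cc1ccnc(NC(c2ccc([N+](=O)[O-])cc2)c2ccc3cccnc3c2O)c1` has not yet been measured. It differs from compound 2 in one place: 4-nitrophenyl in place of 2-methylphenyl on a saturated chain carbon bound to an aromatic carbon and a nitrogen on an aromatic ring. Among the compounds with values here, because both known values in this assay are limits, the data give no measured step on which to base a direction for this change.

With nothing to point either way, compound 3 is expected to give about 60000 nM in this assay, within a range from 15000 nM to 300000 nM, most likely again reported as a limit. The estimated step that the limit leaves unreadable from compound 2 to compound 3 is expected to stay within the usual scatter, with no clear gain or loss in potency.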

Compound 3, half-maximal inhibitory concentration: 530 nM
For compound 3 the middle estimate is 110-fold (2.05 log units) above the measured one; measured number below the stated range.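

In this assay, replacing 2-methylphenyl with 4-nitrophenyl on the saturated chain carbon gives an at least 75-fold lower number from compound 2 to compound 3 (1.87 log units; beyond the scatter), a large change that lies beyond the usual scatter. This shows that the position is not indifferent: with the rest of the structure unchanged, the group on this carbon alone separates a compound that reaches only a limit from one with a measured value. The real size of the step could be greater still, because compound 2 gave a limit rather than a number: the limit of > 40000 nM in this assay, at which 1 of the 3 values shown sits.

The change removes a methyl group and brings in a nitro group in a single move, so the compounds shown cannot tell which part of it matters, and they give no reason for the drop in the number. A plain phenyl on the same chain carbon, or a phenyl ring carrying a nitrile or a carboxylic acid in place of the nitro group, would help show whether the nitro group itself is needed.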